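The source may hold more compounds than are shown below. What is called first, only, known or untested is meant among the compounds shown, and "the series" means these compounds.

Compound 3 `CC(C)(F)CCc1cc(C(F)(F)F)ccc1CNC(=O)Nc1cccc2[nH]ncc12` gives 6 nM in a functional assay for antagonist activity at transient receptor potential cation channel subfamily V member 1 (Homo sapiens); on this read-out higher numbers stand for weaker inhibition and lower numbers for stronger inhibition. On the numbers shown it stands level with compound 1 `CC(C)(C)COc1nc(C(F)(F)F)ccc1CNC(=O)Nc1cccc2[nH]ncc12`, which gives 6 nM; together these are the lowest values of the set, while compound 2 `COCCCc1nc(C(F)(F)F)ccc1CNC(=O)Nc1cccc2[nH]ncc12` gives 12 nM, a gap from compound 3 that is within the scatter. Compound 4 `COCCCc1cc(C(F)(F)F)ccc1CNC(=O)Nc1cccc2[nH]ncc12` differs from compound 3 by methoxymethyl in place of 1-fluoro-1-methylethyl on a saturated chain carbon, two bonds along the chain from an aromatic carbon. Among the compounds with values here, one measured step bears on this change: a 2.0-fold higher number from compound 1 to compound 2 (0.30 log units; within the scatter), which likewise puts a 3-methoxypropyl chain where a branched saturated group had stood, though compound 1 carries its group as neopentyloxy and compounds 1 and 2 share a core unlike that of compounds 3 and 4. Within the data shown here, no step on the core of compound 3 itself has been measured. A step of similar size toward a higher number, still within the scatter, is therefore expected from compound 3 to compound 4, namely a 1.8-fold higher number from compound 3 to compound 4 (0.26 log units; within the scatter). Compound 4 is estimated at 11 nM, within a range from 4 nM to 28 nM.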

Compound 4, half-maximal inhibitory concentration: 8 nM
For compound 4 the middle estimate is 1.4-fold (0.14 log units) above the measured one; the measured number falls inside the stated range.
By their numbers in this assay, from the lowest: compounds 1, 3, 4 and 2 (each within the scatter of the next).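

On the shared core, the exchange of 3-fluoro-3-methylbutyl for 3-methoxypropyl can now be read directly as a 1.3-fold higher number from compound 3 to compound 4 (0.12 log units; within the scatter) in this assay and no longer has to be inferred from a step on another core. The position therefore takes methoxymethyl in place of 1-fluoro-1-methylethyl, and with it a hydrogen-bond acceptor in place of fluorine, with no step beyond the scatter. With a 2.0-fold higher number from compound 1 to compound 2 (0.30 log units; within the scatter) as the second case, both steps to a 3-methoxypropyl chain among these compounds stay within the scatter, on two different cores and from two different branched groups.

On these data alone, whether an amine, a carboxylic acid or a longer chain at this position would give a step beyond the scatter remains open. No supporting measurement is available to explain the size of either step.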